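The source may hold more compounds than are shown below. What is called first, only, known or untested is meant among the compounds shown, and "the series" means these compounds.

Of the compounds shown here, three have been tested in a functional assay on MDA-MB-231 cells (Homo sapiens) for inhibition, read by sulforhodamine B assay, with a stated time of 72 h (a lower number here means a stronger inhibitor of growth, a higher number a weaker inhibitor of growth), and none of them gives a number. Compound 1 (`CCOC(=O)/C=C/c1ccncc1-c1ccc2c(cnn2C)c1`) gives > 10000 nM as a limit of the assay. Compound 3 (`O=C(/C=C/c1ccncc1-c1ccc2cc[nH]c2c1)N1CCOCC1`) gives > 10000 nM as a limit too. Compound 2 (`NNC(=O)CCc1ccncc1-c1ccc2ccccc2c1`) gives > 10000 nM and this is also only a limit. Compound 2 therefore stands with the other two at the limit of > 10000 nM in this assay, at which 3 of the 3 values shown sit, and cannot be ranked against them.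

Compound 4 (`O=C(O)CCc1ccncc1-c1ccc2ccccc2c1`) keeps the core of compound 2 and carries hydroxy in place of aminoamino on a carbonyl carbon so that aminocarbamoyl becomes carboxy. Going by the values given here, no measured pair shows what such a change does in this assay, so the expectation rests on compound 2 at > 10000 nM as its only close reference. The expected change is a step that the limit leaves unreadable from compound 2 to compound 4 and it is expected to stay within the scatter. For compound 4 the estimated value is 12000 nM in a range from 6000 nM to 30000 nM and a report as a limit is the likely outcome.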

Compound 4, concentration for 50% growth inhibition: > 10000 nM
Compound 4 gave a limit, no number (the forecaster's own chance of this, stated with the estimate: 85%); the middle value lies beyond the limit too.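

No step from compound 2 to compound 4 can be read, and both compounds stand at the same limit: the limit of > 10000 nM in this assay, at which 4 of the 4 values shown sit.

The compounds shown leave open what hydroxy in place of aminoamino on a carbonyl carbon does in this assay, and which change to the shared core, if any, would give a number rather than a limit.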